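The compounds below may be only part of what the source reports. "The series", "measured", "known", "first", "only" and "open" are said of these compounds alone.

Measured so far: compound 1 `O=C1/C(=C\c2cccnc2)c2ccccc2N1Cc1ccccc1`, in a functional assay on HL-60 cells (Homo sapiens) for cytotoxicity, read by MTT assay, with a stated time of 72 h, tested at 5 uM (a lower number here means a stronger effect, a higher number a weaker effect of the compound at the concentration tested), compound 1 gives 25.4%; compound 2 `O=C1/C(=C\c2ccccn2)c2ccccc2N1Cc1ccccc1`, in this assay compound 2 gives 24.7%.

Compound 2 holds the lower of the two numbers, but compound 1 lies within the scatter of it: a number 0.7 percentage points lower from compound 1 to compound 2 (within the scatter). Compound 3 `O=C1/C(=C\c2cc[n+]([O-])cc2)c2ccccc2N1Cc1ccccc1` is not yet measured. Its change from compound 2 is a group of 7 heavy atoms (5 carbon, 1 nitrogen, 1 oxygen; one six-membered aromatic ring with 1 hetero atom) in place of a group of 6 heavy atoms (5 carbon, 1 nitrogen; one six-membered aromatic ring with 1 hetero atom), on a double-bonded chain carbon bound to a double-bonded ring carbon. Among the measured compounds shown here, only the step from compound 1 to compound 2, a shift of the ring nitrogen at the same place, bears on it, and that step stayed within the scatter. For the measured compounds named here, no measured step covers the entering oxygen-bearing ring. Compound 3 is therefore expected to give about 28%, between 12% and 46%. The expected step from compound 2 to compound 3 is a number 3.3 percentage points higher from compound 2 to compound 3 (within the scatter), none beyond the scatter.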

Compound 3, a percentage reported as activity, at one concentration (the size of the read-out at that concentration, not a potency): 22%
Compound 3: the middle estimate sits 6 percentage points above what was measured; the range from low to high includes it.
By their numbers in this assay, from the lowest: compounds 3, 2 and 1 (each within the scatter of the next).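

In this assay, the step of a number 2.7 percentage points lower from compound 2 to compound 3 (within the scatter) and the step of a number 3.4 percentage points lower from compound 1 to compound 3 (within the scatter) show that the group of 7 heavy atoms, with its added oxygen, leaves the read-out within the scatter at this place on a double-bonded chain carbon bound to a double-bonded ring carbon. The tolerated change here is thus no longer only a shift of the ring nitrogen. No available measurement explains this result.

Still open, on these data alone, is whether a morpholine, a carboxylic acid or a longer chain at this place would move the number beyond the scatter.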